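Capping the Hydroxy Group: From Phenol to Methyl Ether

A few compounds are considered here, and "the series" means these few. Any claim that something is new, unique, unknown or untested is made for them only; others in the source may bear on it.

Measured so far:
Compound 1, `COc1ccc(-c2cc3ccccc3nc2/C=C/C(=O)c2ccccc2)cc1`: 1410 nM
Compound 2, `COc1ccc(-c2cc3ccccc3nc2/C=C/C(=O)c2ccc(O)cc2)cc1`: 8970 nM

In a functional assay on NCI-H1299 cells (Homo sapiens) for antiproliferative activity, read by XTT assay, with a stated time of 72 h (a lower number here means a stronger inhibitor, a higher number a weaker inhibitor), compound 2 gives the highest of the two numbers; the nearest is compound 1, and the step of a 6.4-fold higher number from compound 1 to compound 2 (0.80 log units; beyond the scatter) came with a hydroxy in place of hydrogen on an aromatic carbon. Compound 3, `COc1ccc(C(=O)/C=C/c2nc3ccccc3cc2-c2ccc(OC)cc2)cc1`, differs from compound 2 by methyl in place of hydrogen on an oxygen on an aromatic ring. Among the compounds with values here, no measured step covers methyl on oxygen, so only the hydroxy step bears on it, and that step was modest. A number between compound 1 and compound 2 is expected, so compound 3 is estimated at 3000 nM (range 1000 nM to 9000 nM), an expected step of a 3.0-fold lower number from compound 2 to compound 3 (0.48 log units; beyond the scatter).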

Compound 3, half-maximal inhibitory concentration: 6420 nM
The estimate for compound 3 lay 2.1-fold (0.33 log units) below the measured number; the range from low to high includes it.
By their numbers in this assay, from the lowest: compound 1; then compounds 3 and 2 (each within the scatter of the next).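

In this assay, putting methyl on the oxygen makes no clear difference: a 1.4-fold lower number from compound 2 to compound 3 (0.15 log units; within the scatter) shows hydroxy and methoxy cannot be told apart here. Capping the hydroxy group also does not restore the number of the unsubstituted ring, as a 4.6-fold higher number from compound 1 to compound 3 (0.66 log units; beyond the scatter) shows. Nothing measured here explains this result.

On these data alone, whether a longer chain on this oxygen would behave like methyl remains open. So does whether an amine in place of the methoxy would bring the number closer to that of compound 1.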